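A few compounds are considered here, and "the series" means these few. Any claim that something is new, unique, unknown or untested is made for them only; others in the source may bear on it.

Measured so far in a functional assay on liver (Rattus norvegicus, strain Sprague-Dawley) for inhibition, with a stated time of 1 h; on this read-out lower numbers stand for stronger inhibition and higher numbers for weaker inhibition:

- compound 1 `COc1cc(C2Oc3cc([C@H]4Oc5cc(O)cc(O)c5C(=O)[C@@H]4O)ccc3OC2COC(=O)c2ccccc2)ccc1O`: 12700 nM
- compound 2 `COc1cc(C2Oc3cc([C@H]4Oc5cc(O)cc(O)c5C(=O)[C@@H]4O)ccc3OC2COC(=O)c2ccc([N+](=O)[O-])cc2)ccc1O`: 12600 nM
- compound 3 `COc1cc(C2Oc3cc([C@H]4Oc5cc(O)cc(O)c5C(=O)[C@@H]4O)ccc3OC2COC(=O)c2ccc(OC)c(OC)c2)ccc1O`: 16000 nM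

These three compounds keep the shared core and differ only in the group on a carbonyl carbon. Compound 3, at 16000 nM, sits level with the other two, since a 1.3-fold higher number from compound 1 to compound 3 (0.10 log units; within the scatter) and a 1.3-fold higher number from compound 2 to compound 3 (0.10 log units; within the scatter) both stay within the scatter. The nitro swap tells the same story: a 1.0-fold lower number from compound 1 to compound 2 (0.00 log units; within the scatter), also within the scatter.

The next compound is compound 4 `COc1cc(C2Oc3cc([C@H]4Oc5cc(O)cc(O)c5C(=O)[C@@H]4O)ccc3OC2COC(=O)/C=C/c2ccc(Br)cc2)ccc1O`. Compared with compound 3, it carries this change: 2-(4-bromophenyl)ethenyl in place of 3,4-dimethoxyphenyl on a carbonyl carbon. In words, 2-(4-bromophenyl)ethenyl takes the place of 3,4-dimethoxyphenyl on a carbonyl carbon, which adds a double bond outside aromatic rings.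

The three measured steps are the best guide, as all of them are swaps at this same carbon, and none moved the number beyond the scatter. However, no measured compound carries the double bond or the bromine, so the guide is only partial and the range has to stay wide. No step beyond the scatter is therefore expected in this assay. The expected step is a 1.3-fold lower number from compound 3 to compound 4 (0.12 log units; within the scatter). The estimate for compound 4 is 12000 nM, with an expected range from 5500 nM to 24000 nM.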

Compound 4, half-maximal inhibitory concentration: 16300 nM
Beside the measured number, compound 4's estimate is 1.4-fold (0.13 log units) below it, and the stated range covers the measured number.
By their numbers in this assay, from the lowest: compounds 2, 1, 3 and 4 (each within the scatter of the next).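

In this assay the new group leaves the number level against all three earlier esters: the swap gives a 1.0-fold higher number from compound 3 to compound 4 (0.01 log units; within the scatter) and the comparisons with the other two give a 1.3-fold higher number from compound 2 to compound 4 (0.11 log units; within the scatter) and a 1.3-fold higher number from compound 1 to compound 4 (0.11 log units; within the scatter). For the compounds shown here, compounds 1, 2 and 3 carry only phenyl groups on this carbonyl carbon, so compound 4 is the first here to show that 2-(4-bromophenyl)ethenyl, with its double bond outside aromatic rings and its bromine, can stand at this position without a step beyond the scatter. The position now accepts a wider range of groups than the earlier swaps alone could show, although nothing available says why the number stays level.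

From the compounds shown here alone, all four groups on this carbonyl carbon still hold a six-membered aromatic ring of carbon only, so it remains open how the number would respond to a group without one, such as a plain saturated carbon chain, or to one carrying an amine or a carboxylic acid. The compounds shown also leave open whether the ester link matters, since an amide in its place would be needed to test that.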